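This account rests on a few compounds, and the source may have more. Where it says the series, first, only, none or still open, it means among the compounds named here.

Measured compounds:
Compound 1, `Cc1cc(C(N)=O)nn1Cc1cc(Cl)ccc1OCc1ccccc1`, gives 126 nM
Compound 2, `Cc1cc(C(=O)NCc2ccncc2)nn1Cc1cc(Cl)ccc1OCc1ccccc1`, gives 79.4 nM
Compound 3, `Cc1cc(C(=O)NN2CCCCC2)nn1Cc1cc(Cl)ccc1OCC(C)C`, gives 200 nM

All three were tested in an assay on CHO-K1 cells for displacement of a labelled ligand from prostaglandin E2 receptor EP1 subtype (Homo sapiens); on this read-out lower numbers stand for stronger inhibition and higher numbers for weaker inhibition. Compound 2 shows the smallest of the three numbers, though compound 1 lies within the usual scatter of it; only compound 3 lies beyond it. Within the data shown here, the single one-place step known here, a 1.6-fold lower number from compound 1 to compound 2 (0.20 log units; within the scatter), stays within the scatter. Compound 4, `Cc1cc(NC(=O)c2ccccc2)nn1Cc1cc(Cl)ccc1OCc1ccccc1`, differs from compound 2 as follows: benzamido in place of ((pyridin-4-yl)methyl)carbamoyl on an aromatic carbon. Among the measured compounds shown here, no measured step covers this reversal of the amide. For the measured compounds named here, the only related comparison, the step into compound 2, moved the number little, so a shift no larger than the scatter is expected, a 2.0-fold higher number from compound 2 to compound 4 (0.30 log units; within the scatter). Compound 4 is estimated at 160 nM, with a range from 50 nM to 500 nM.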

Compound 4, half-maximal inhibitory concentration: 15.9 nM
Estimate against measurement, compound 4: 10-fold (1.00 log units) above; the whole stated range lies above it.
By their numbers in this assay, from the lowest: compound 4; then compounds 2, 1 and 3 (each within the scatter of the next, the first and the last beyond it).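

Placing benzamido on this aromatic carbon of the shared core gives a 5.0-fold lower number from compound 2 to compound 4 (0.70 log units; beyond the scatter) and a 7.9-fold lower number from compound 1 to compound 4 (0.90 log units; beyond the scatter) in this assay, so this position responds to changes in the attached group by more than the scatter, which the earlier step of a 1.6-fold lower number from compound 1 to compound 2 (0.20 log units; within the scatter) did not show. Nothing available here bears on the reason for this gain. As far as these compounds go, the change alters both the direction of the amide and the attached ring, and the share of each remains open. From the compounds shown here alone, how a pyridine ring on the reversed amide, or a sulfonamide or plain amine at this carbon, would compare also remains open.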